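This account rests on a few compounds, and the source may have more. Where it says the series, first, only, none or still open, it means among the compounds named here.

Of the compounds shown here, three have been measured in a functional assay for inhibition of Polyunsaturated fatty acid 5-lipoxygenase (Homo sapiens); on this read-out higher numbers stand for weaker inhibition and lower numbers for stronger inhibition. Compound 1 `O=C(O)[C@@H](c1ccc(OCc2ccc3ccccc3n2)cc1)C1CCCC1` gives 60 nM. Compound 2 `O=C(O)/C=N/OC(c1ccc(OCc2nc(-c3ccccc3)cs2)cc1)C1CCCCC1` gives 21 nM. Compound 3 `C/C(=N\OC(c1ccc(OCc2nc(-c3ccccc3)cs2)cc1)C1CCCCC1)C(=O)O` gives 20 nM, the lowest number of the three, yet compound 2 and compound 3 sit within the scatter of each other, so no order between them can be read; only compound 1 stands clearly apart with its higher number. The one single-point step among these, a 1.1-fold lower number from compound 2 to compound 3 (0.02 log units; within the scatter), changes only the acid-bearing side chain and lies within the scatter.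

Compound 4 `C/C(=N\OC(c1ccc(OCc2nc3ccccc3s2)cc1)C1CCCCC1)C(=O)O` has not been measured. It differs from compound 3 in one place: 1,3-benzothiazol-2-yl in place of 4-phenyl-1,3-thiazol-2-yl on a saturated chain carbon bound to an oxygen on an aromatic ring. Among the measured compounds shown here, none of the measured steps touches this part of the molecule, so there is no direct guide; the step from compound 2 to compound 3 concerns a different position, and compound 1 differs from compound 3 in more than one place. With no evidence either way, compound 4 is expected to stay near compound 3, with perhaps a modest rise in the number, an estimated step of a 2.5-fold higher number from compound 3 to compound 4 (0.40 log units; beyond the scatter). Compound 4 is therefore estimated at 50 nM, within a range from 15 nM to 200 nM.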

Compound 4, half-maximal inhibitory concentration: 60 nM
Compound 4: the middle estimate sits 1.2-fold (0.08 log units) below what was measured, and the stated range covers the measured number.
By their numbers in this assay, from the lowest: compounds 3 and 2 (each within the scatter of the next); then compounds 1 and 4 (each within the scatter of the next).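

In this assay, the step of a 3.0-fold higher number from compound 3 to compound 4 (0.48 log units; beyond the scatter) shows that the group on a saturated chain carbon bound to an oxygen on an aromatic ring can shift the read-out, whereas the change to the acid-bearing side chain, a 1.1-fold lower number from compound 2 to compound 3 (0.02 log units; within the scatter), could not be told from the scatter. The shift appears even though 4-phenyl-1,3-thiazol-2-yl and 1,3-benzothiazol-2-yl have the same kinds of ring and the same hydrogen-bond donor and acceptor counts, and differ in heavy-atom count and in how their rings are joined. No measurement here explains the higher number.

This single pair cannot separate the effect of heavy-atom count from that of ring arrangement. On these data alone, how a plain 1,3-thiazol-2-yl group, without the phenyl ring, would behave at this position remains open.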